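Capping the Amine Chain on a Decyl-Aryl Oxadiazole Core

The source may report more compounds than this note shows. Statements on the series, on what has been measured and on what is new or still open speak of the compounds shown alone.

Compound 1 `CCCCCCCCCCc1ccc(-c2noc(CCCN)n2)cc1`: 67%
Compound 2 `CCCCCCCCCCc1ccc(-c2noc(CCCNC)n2)cc1`: 45%
Compound 3 `CCCCCCCCCCc1ccc(-c2noc(CC3CCNC3)n2)cc1`: 44%

In an assay on HeLa cells for inhibition of sphingosine-1-phosphate transporter SPNS2 (Mus musculus), read by LC-MS, tested at 2 uM (a lower number here means less inhibition, a higher number more inhibition at the concentration tested (going by the name of the read-out)), compound 2 gives 45%, the second highest of the three numbers; compound 3 stands within the scatter of it (a number 1 percentage points lower from compound 2 to compound 3 (within the scatter)), while compound 1 lies clearly higher (a number 22 percentage points lower from compound 1 to compound 2 (beyond the scatter)). Compound 4 `CCCCCCCCCCc1ccc(-c2noc(CC(CN)OC(C)=O)n2)cc1` differs from compound 2 as follows: a group of 7 heavy atoms (4 carbon, 1 nitrogen, 2 oxygen; no ring) in place of a group of 4 heavy atoms (3 carbon, 1 nitrogen; no ring), on a saturated chain carbon bound to an aromatic carbon. Among the measured compounds shown here, the only step that bears on it is the one from compound 1 to compound 2, where a methyl on the amine nitrogen lowered the number modestly; compound 4 again carries an unsubstituted amine nitrogen, but the entering group has no measured counterpart. A modest rise is therefore expected, a number 10 percentage points higher from compound 2 to compound 4 (within the scatter), with wide uncertainty. Compound 4 is estimated at 55%, between 35% and 75%.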

Compound 4, a percentage reported as inhibition, at one concentration (the size of the read-out at that concentration, not a potency): 0%
Compound 4: middle estimate off by 55 percentage points, on the high side; the measured number lies below the stated range.
By their numbers in this assay, from the lowest: compound 4; then compounds 3 and 2 (each within the scatter of the next); then compound 1.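

In this assay, acetoxy in place of hydrogen on a saturated chain carbon bound to two saturated chain carbons gives the largest change seen so far, with a number 67 percentage points lower from compound 1 to compound 4 (beyond the scatter). Compound 4 keeps the unsubstituted amine nitrogen of compound 1, yet the number still drops below those of the other two amines, with a number 45 percentage points lower from compound 2 to compound 4 (beyond the scatter) and a number 44 percentage points lower from compound 3 to compound 4 (beyond the scatter), so this chain carbon matters as well as the amine. Nothing measured here accounts for the drop. From the compounds shown here alone, whether a hydroxyl or a methyl at this chain carbon would give a similar loss remains open. So does whether a longer ester such as propionyloxy would behave like acetoxy.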